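This account rests on a few compounds, and the source may have more. Where it says the series, first, only, none or still open, it means among the compounds named here.

Of the compounds shown here, three sharing one core have been tested in a functional assay on A549 cells (Homo sapiens) for antiproliferative activity, read by MTT assay, with a stated time of 24 h; a lower number here means a stronger inhibitor, a higher number a weaker inhibitor. Compound 1 `COc1ccc(/C=C/C(=O)c2cc(-c3ccc(OC)c(OC)c3)n3nc(-c4ccccc4)cc3n2)cc1` gives 19300 nM in this assay. Compound 2 `COc1ccc(-c2cc(/C=C/C(=O)c3ccc(C)c(C)c3)nc3cc(-c4ccccc4)nn23)cc1OC` gives 9300 nM, and compound 3 `COc1cc(-c2cc(/C=C/C(=O)c3ccc(C)c(C)c3)nc3cc(-c4ccccc4)nn23)cc(OC)c1OC` gives 10600 nM. Among these three numbers compound 2 has the lowest, though its gap to compound 3 is within the scatter, so the two cannot be told apart; only compound 1 stands clearly apart from it. The two known steps are a 2.1-fold lower number from compound 1 to compound 2 (0.32 log units; beyond the scatter) and a 1.1-fold higher number from compound 2 to compound 3 (0.06 log units; within the scatter).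

Compound 4 `COc1ccc(-c2cc(/C=C/C(=O)c3ccc(Cl)cc3)nc3cc(-c4ccccc4)nn23)cc1OC` is built from compound 2 by one change: 4-chlorophenyl in place of 3,4-dimethylphenyl on a carbonyl carbon. Neither measured step tests this exact exchange. The step from compound 1 to compound 2 touched the same part of the molecule, but it changed both the aryl group and its connection to the carbonyl, and it was only modest; the step from compound 2 to compound 3 concerned a different ring and stayed within the scatter. Within the data shown here, with no direct precedent, the expectation for compound 4 is a step of a 1.2-fold higher number from compound 2 to compound 4 (0.07 log units; within the scatter), that is, no shift beyond the scatter in either direction. Compound 4 is therefore estimated at 11000 nM in this assay, within a range from 4500 nM to 27000 nM.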

Compound 4, half-maximal inhibitory concentration: 15400 nM
For compound 4 the middle estimate is 1.4-fold (0.15 log units) below the measured one; the measured number falls inside the stated range.
By their numbers in this assay, from the lowest: compounds 2, 3, 4 and 1 (each within the scatter of the next, the first and the last beyond it).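

Compound 4 gives the only step shown that exchanges the aryl group on the carbonyl carbon while leaving the rest of the molecule as it was: in this assay this exchange gives a 1.7-fold higher number from compound 2 to compound 4 (0.22 log units; within the scatter) and so does not separate 4-chlorophenyl from 3,4-dimethylphenyl. The other new step, a 1.3-fold lower number from compound 1 to compound 4 (0.10 log units; within the scatter) in the same assay, is also within the scatter, whereas a 2.1-fold lower number from compound 1 to compound 2 (0.32 log units; beyond the scatter) is beyond it, so moving to the 2-((4-chlorophenyl)carbonyl)ethenyl arrangement does not clearly separate compound 4 from compound 1, even though compound 2 stands apart from compound 1 by a modest margin. No measurement here explains why these numbers fall as they do.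

Among these compounds, only two aryl groups can be compared at this place, so it remains open whether a different group on the carbonyl carbon, such as 4-aminophenyl, 4-carboxyphenyl or a piperidine ring, would move the number beyond the scatter. Going by these compounds, it is also open whether the same exchange would read the same way on the core of compound 3, which carries one more methoxy group.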